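This account rests on a few compounds, and the source may have more. Where it says the series, first, only, none or still open, it means among the compounds named here.

The measured compounds are compound 1, `O=C1C(CO)=C[C@@H](O)[C@@H](O)[C@@H]1Br`; compound 2, `O=C1C(CO)=C[C@@H](O)[C@@H](O)[C@@H]1Cl`; and compound 3, `COc1cc(O)c(C(=O)c2c(C)cc(O)cc2OC)c(O)c1Cl`.

In a functional assay on MCF7 cells (Homo sapiens) for cytotoxicity, read by sulforhodamine B assay, with a stated time of 3 days (on this read-out lower numbers stand for stronger inhibition and higher numbers for weaker inhibition), compound 1 gives 9700 nM. Compound 2 reaches only a limit of the assay, > 20000 nM. Compound 3 likewise sits at a limit, > 20000 nM. Compound 1 thus holds the only number shown; the other two values are limits (the limit of > 20000 nM in this assay, at which 2 of the 3 values shown sit). Among the compounds with values here, the one measured step, an at least 2.0-fold higher number from compound 1 to compound 2 (0.31 log units; beyond the scatter), concerns a change of halogen and says nothing about configuration. Compound 4, `O=C1C(CO)=C[C@@H](O)[C@@H](O)[C@H]1Br`, differs from compound 1 only as follows: the two compounds have the same atoms and bonds and differ only in configuration as drawn: 1 of 3 stereo elements differ; a stereocentre at a saturated ring carbon is drawn S in compound 1 and R in compound 4. Within the data shown here, with no measured step bearing on such a change, no step beyond the scatter is expected in this assay. Compound 4 is therefore estimated at 12000 nM (from 4000 nM to 30000 nM), an expected step of a 1.2-fold higher number from compound 1 to compound 4 (0.09 log units; within the scatter).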

Compound 4, half-maximal inhibitory concentration: 9700 nM
Beside the measured number, compound 4's estimate is 1.2-fold (0.09 log units) above it; the measured number falls inside the stated range.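

Inverting the drawn configuration at this saturated ring carbon, from S to R, gives no change at the digits printed from compound 1 to compound 4 (within the scatter) in this assay. Among the steps shown, only the change of halogen, an at least 2.0-fold higher number from compound 1 to compound 2 (0.31 log units; beyond the scatter), moves the number beyond the scatter. The comparison isolates configuration alone: the fact that compounds 1 and 4 differ only in the configuration as drawn

The compounds shown leave open how an amine or a longer chain in place of bromo would read in this assay. They also leave open whether changing the other two stereo elements would matter, or whether the same inversion would matter with chloro in place of bromo.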